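The source may report more compounds than this note shows. Statements on the series, on what has been measured and on what is new or still open speak of the compounds shown alone.

Measured compounds in the series:

compound 1, `CCO/N=C/Nc1cc(Cl)c(CC)c(Cl)c1`, gives 4.8
compound 2, `CCO/N=C/Nc1cc(Cl)c(SSCC)c(Cl)c1`, gives 5
compound 3, `C#CCc1c(Cl)cc(N/C=N/OCCCC)cc1Cl`, gives 4.4

In a physicochemical assay for lipophilicity, measured as octanol-water partition (a higher number here means a more lipophilic compound, a lower number a more polar compound), compound 3 stands lowest of the three measured numbers; compound 1 sits nearest to it, and compound 2 sits furthest from it, both beyond the scatter. Among the measured compounds shown here, the one measured step with a single change, a number 0.20 log units higher from compound 1 to compound 2 (within the scatter), concerns a substituent on the aromatic carbon and not the chain on the oxygen, so it does not bear directly on the step now considered.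

Compound 4, `C#CCc1c(Cl)cc(N/C=N/OC/C=C/Cl)cc1Cl`, differs from compound 3 in one place: 2-chloroethenyl in place of propyl on a saturated chain carbon bound to an oxygen. The swap keeps the count of heavy atoms the same and adds no donors or acceptors. For the measured compounds named here, with no measured step at this position, the expectation rests on the like-for-like size of the groups alone, and a step of roughly no size beyond the scatter, or a slight fall, is expected: a number 0.10 log units lower from compound 3 to compound 4 (within the scatter).

Compound 4 is therefore estimated at 4.3 in this assay, with a range from 3.9 to 4.7.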

Compound 4, partition coefficient: 3.9
Compound 4: the middle estimate sits 0.40 log units above what was measured; measured number inside the range.
By their numbers in this assay, from the lowest: compound 4; then compound 3; then compounds 1 and 2 (each within the scatter of the next).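

Notes on the chain on the oxygen: in this assay this position is not silent, with a number 0.50 log units lower from compound 3 to compound 4 (beyond the scatter) as the first measured step at this place. The change from propyl to 2-chloroethenyl leaves the heavy-atom count the same and brings no hydrogen-bond donors or acceptors, so matching counts do not make these two groups interchangeable here. This step stands apart from the only earlier one, on an aromatic carbon, where the series gave a number 0.20 log units higher from compound 1 to compound 2 (within the scatter). No measurement shown accounts for the direction or size of the new step.

As far as these compounds go, whether the step follows the chlorine, the double bond or both stays open, and an allyl group or a chloropropyl chain at this place would separate them. Also open, from the compounds shown here alone, is whether the same swap gives a similar step on the ethyl-bearing core of compound 1.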